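Acetoxy on the Ring Double Bond: Outlook for Compound 4

A few compounds are considered here, and "the series" means these few. Any claim that something is new, unique, unknown or untested is made for them only; others in the source may bear on it.

Compound 2 `CCS(=O)(=O)N[C@@H]1C=C[C@H](OC(C)=O)[C@@H](COC(C)=O)O1` holds the lowest of the two numbers obtained so far: in a functional assay on A549 cells (Homo sapiens) for cytotoxicity, read by MTT assay, with a stated time of 24 h (on this read-out higher numbers stand for weaker inhibition and lower numbers for stronger inhibition), compound 2 gives 280000000 nM. Compound 1 `CC(=O)OC[C@H]1O[C@H](NS(N)(=O)=O)C=C[C@@H]1OC(C)=O` gives 704000000 nM in this assay. Compound 3 `CCS(=O)(=O)N[C@@H]1C=C[C@@H](OC(C)=O)[C@@H](COC(C)=O)O1` gives only a limit of the assay, > 1000000000 nM, and so contributes no number.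

Two steps have been measured in the series. a 2.5-fold lower number from compound 1 to compound 2 (0.40 log units; beyond the scatter). an at least 3.5-fold higher number from compound 2 to compound 3 (0.55 log units; beyond the scatter); this step rests on (the fact that compounds 2 and 3 differ only in the configuration as drawn), and compound 3 sits at the limit of > 1000000000 nM in this assay, at which 1 of the 3 values shown sits.

Compound 4 `CCS(=O)(=O)N[C@H]1O[C@H](COC(C)=O)[C@@H](OC(C)=O)C=C1OC(C)=O` is the next member, not yet measured. It differs from compound 2 in one place: acetoxy in place of hydrogen on a double-bonded ring carbon. Neither measured step concerns this part of the shared core. The step to compound 1 alters the group on the sulfonyl sulfur, and the step to compound 3 alters only configuration, so neither bears directly on the change to compound 4. Among the compounds with values here, with the small spread of numbers in this assay and no step of the same kind to lean on, the expectation is a number close to that of compound 2, with no step beyond the scatter: the estimated step is a 1.1-fold higher number from compound 2 to compound 4 (0.03 log units; within the scatter). The estimate for compound 4 in this assay is 300000000 nM, expected between 100000000 nM and 1000000000 nM.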

Compound 4, half-maximal inhibitory concentration: 21900000 nM
For compound 4 the middle estimate is 14-fold (1.14 log units) above the measured one; the whole stated range lies above it.
By their numbers in this assay, from the lowest: compound 4; then compound 2; then compound 1. At a limit, above all of these: compound 3.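

In this assay, the double-bonded ring carbon next to the ring atom that bears a (ethylsulfonyl)amino group proves to be a responsive position: acetoxy in place of hydrogen there gives a 13-fold lower number from compound 2 to compound 4 (1.11 log units; beyond the scatter). Within the data shown here, the earlier steps changed only the group on the sulfonyl sulfur or the configuration as drawn, so this is the first evidence that the series responds to substitution on the ring double bond, and the added acetoxy is tolerated in this read-out rather than costing activity. The data shown offer nothing that accounts for the size of this step, and no cause can be assigned to it.

As far as these compounds go, whether the step belongs to acetoxy specifically remains open, since a hydroxy, methoxy or amine group at this same carbon would be needed to separate the acetoxy group from substitution at the position in general. Also open, from the compounds shown here alone, is whether the step carries over to the core of compound 1, with amino on the sulfonyl sulfur, or to the configuration of compound 3, which gives only a limit of the assay, > 1000000000 nM.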